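Following a Thiophene Swap from Compound 3 to Compound 4

The source may report more compounds than this note shows. Statements on the series, on what has been measured and on what is new or still open speak of the compounds shown alone.

Measured so far in a functional assay on MES-SA cells (Homo sapiens) for antiproliferative activity, read by resazurin assay, with a stated time of 72 h; a lower number here means a stronger inhibitor, a higher number a weaker inhibitor:
- compound 1 `COc1cc(/C=C\c2cc3ccccc3s2)cc(OC)c1OC` gives 13 nM
- compound 2 `COc1cc(/C=C/c2cc3ccccc3s2)cc(OC)c1OC` gives "not determined" (no result reported)
- compound 3 `COc1cc(/C=C\c2ccsc2)cc(OC)c1OC` gives "not determined" (no result reported)

Compound 3 therefore has no single number and offers no measured starting point. Among the compounds with values here, the only number belongs to compound 1. Worth noting is the fact that compounds 1 and 2 differ only in the configuration as drawn, yet compound 2 yields no value for comparison.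

The next molecule, compound 4 `COc1csc(/C=C\c2cc(OC)c(OC)c(OC)c2)c1`, has not yet been measured. The change 4-methoxythiophen-2-yl in place of thiophen-3-yl on a double-bonded chain carbon bound to a double-bonded chain carbon places 4-methoxythiophen-2-yl in place of thiophen-3-yl on a double-bonded chain carbon bound to a double-bonded chain carbon.

Within the data shown here, no measured step shows what such a swap does in this assay, so any prediction is uncertain. Among the measured compounds shown here, the only available anchor is compound 1 at 13 nM, and a moderate step towards weaker inhibition from that value, beyond the usual scatter, is expected. For compound 4 the estimated half-maximal inhibitory concentration is 60 nM, with an expected range from 10 nM to 400 nM.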

Compound 4, half-maximal inhibitory concentration: 25 nM
For compound 4 the middle estimate is 2.4-fold (0.38 log units) above the measured one; measured number inside the range.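

Within the data shown here, with no single number for compound 3, compound 4 at 25 nM forms no step from compound 3 in this assay. The compounds shown leave open what 4-methoxythiophen-2-yl in place of thiophen-3-yl does on its own, and nothing given here accounts for the value of compound 4.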